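Swapping nitro for fluoro in compound 3

The compounds below may be only part of what the source reports. "The series", "measured", "known", "first", "only" and "open" are said of these compounds alone.

Compound 1 `COc1ccc(C(=O)/C=C\Nc2ccc(-c3nc4cc(OC)c(OC)c(OC)c4s3)cc2C)cc1F` gives 1200 nM
Compound 2 `COc1ccc(C(=O)/C=C\Nc2ccc(-c3nc4cc(OC)c(OC)c(OC)c4s3)cc2)cc1O` gives 14100 nM
Compound 3 `COc1ccc(C(=O)/C=C\Nc2ccc(-c3nc4cc(OC)c(OC)c(OC)c4s3)cc2)cc1[N+](=O)[O-]` gives 11400 nM

All three were measured in a functional assay on HeLa cells (Homo sapiens) for antiproliferative activity, read by sulforhodamine B assay, with a stated time of 48 h (on this read-out higher numbers stand for weaker inhibition and lower numbers for stronger inhibition), whereas compound 4 `COc1ccc(C(=O)/C=C\Nc2ccc(-c3nc4cc(OC)c(OC)c(OC)c4s3)cc2)cc1F` has yet to be tested. Compound 3 lies within the scatter of compound 2, and compound 1 shows a clearly lower number. Compound 4 has fluoro in place of nitro on an aromatic carbon. Going by the values given here, the only measured step of this kind, a 1.2-fold lower number from compound 2 to compound 3 (0.09 log units; within the scatter), offers little guidance by itself. Compound 1, at 1200 nM, also carries 3-fluoro-4-methoxyphenyl, but with an additional methyl group, so only part of its lower number is expected to carry over. The expected step is a 2.9-fold lower number from compound 3 to compound 4 (0.45 log units; beyond the scatter), toward a lower number. Compound 4 is estimated at 4000 nM, with a range from 1200 nM to 13000 nM.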

Compound 4, half-maximal inhibitory concentration: 7300 nM
For compound 4 the middle estimate is 1.8-fold (0.26 log units) below the measured one; measured number inside the range.
By their numbers in this assay, from the lowest: compound 1; then compounds 4, 3 and 2 (each within the scatter of the next).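

In this assay, fluoro, nitro and hydroxy on this aromatic carbon, ortho to a methoxy group, stay within the scatter of one another (a 1.6-fold lower number from compound 3 to compound 4 (0.19 log units; within the scatter); a 1.9-fold lower number from compound 2 to compound 4 (0.29 log units; within the scatter)). Going by these compounds alone, the only step here beyond the scatter comes from the other place of change, where hydrogen stands in place of methyl (a 6.1-fold higher number from compound 1 to compound 4 (0.78 log units; beyond the scatter)), so the lower number of compound 1 goes with its methyl group and not with fluoro alone. Nothing available explains these numbers.

As far as these compounds go, it remains open whether an amine or a carboxylic acid on this carbon would move the number beyond the scatter. From the compounds shown here alone, it also remains open whether the methyl group would give a similar step alongside nitro or hydroxy.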